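The source may report more compounds than this note shows. Statements on the series, on what has been measured and on what is new or still open speak of the compounds shown alone.

Compound 1 `CC(C)(C)c1ccc(NC(=O)c2ccc(-c3ccccn3)cc2)cc1` is one of three compounds whose activity has been measured in a functional assay on Dorsal root ganglion for antagonist activity at transient receptor potential cation channel subfamily V member 1 (Rattus norvegicus) (on this read-out lower numbers stand for stronger inhibition and higher numbers for weaker inhibition), where compound 1 gives 31 nM. Compound 3 `Cc1cccnc1-c1ccc(C(=O)Nc2ccc(C(C)(C)C)cc2)cc1` gives 31 nM, level with compound 1 at the digits shown, so that the two together stand at the lowest number of the three. Compound 2 `CC(C)(C)c1ccc(NC(=O)c2ccc(-c3ccccc3)cc2)cc1` gives 3600 nM, the number furthest from compound 1. The steps between them are a 120-fold higher number from compound 1 to compound 2 (2.06 log units; beyond the scatter), no change at the digits printed from compound 1 to compound 3 (within the scatter) and a 120-fold lower number from compound 2 to compound 3 (2.06 log units; beyond the scatter). Both large steps involve exchanging the ring on the far side of the amide, while the methyl step leaves the number unchanged.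

Compound 4 `CC(C)c1ccc(NC(=O)c2ccc(-c3ccccn3)cc2)cc1` has not yet been measured. It differs from compound 1 by hydrogen in place of methyl on a saturated chain carbon bound to an aromatic carbon and two saturated chain carbons, which is tert-butyl becoming isopropyl. Among the compounds with values here, none of the measured steps touches this end of the molecule, so they bear on the change only loosely: they show that a small alteration can leave the number where it is, as in compound 3, while a different kind of change can move it greatly. For a removal of one carbon from a chain, a step of modest size is expected, more likely toward a higher number than a lower one. Compound 4 is therefore estimated at 70 nM, within a range of 15 nM to 350 nM, which means an expected step of a 2.3-fold higher number from compound 1 to compound 4 (0.35 log units; beyond the scatter).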

Compound 4, half-maximal inhibitory concentration: 38 nM
Beside the measured number, compound 4's estimate is 1.8-fold (0.27 log units) above it, within the range that was stated.
By their numbers in this assay, from the lowest: compounds 1, 3 and 4 (each within the scatter of the next); then compound 2.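

In this assay, replacing tert-butyl with isopropyl gives a 1.2-fold higher number from compound 1 to compound 4 (0.09 log units; within the scatter) and so leaves no difference that can be told apart from the ordinary spread of repeat measurements. Within the data shown here, this is the first view of this end of the molecule, and it shows that one methyl can leave the saturated chain carbon there without a clear cost, whereas exchanging the ring gave a 120-fold higher number from compound 1 to compound 2 (2.06 log units; beyond the scatter) and stood well beyond that spread. No measurement in hand explains why the number holds when this methyl is lost.

The compounds shown leave open how much change this place will bear: an ethyl group, a trifluoromethyl group, a carboxylic acid or an amine in place of tert-butyl could each hold the number or move it far. They also leave open whether isopropyl would behave the same way alongside the other rings, since the swap from tert-butyl to isopropyl is seen here only in the setting of compound 1.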